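Compound 3: pyridin-3-yl in place of phenyl

This account rests on a few compounds, and the source may have more. Where it says the series, first, only, none or still open, it means among the compounds named here.

Within the data shown here, in a functional assay on L1210 cells (Mus musculus) for inhibition (a lower number here means a stronger inhibitor, a higher number a weaker inhibitor), compound 1 `CC(C)CN(CC(=O)N(CC(C)C)NC(=O)OCc1ccccc1)/N=C/c1cccc(B(O)O)c1` gives 21200 nM and compound 2 `CC(C)CN(NC(=O)OCc1ccccc1)C(=O)CN(Cc1ccccc1)/N=C/c1cccc(B(O)O)c1` gives 16200 nM, so compound 2 stands within the scatter of the only other measured value. Compound 3 `CC(C)CN(NC(=O)OCc1ccccc1)C(=O)CN(Cc1cccnc1)/N=C/c1cccc(B(O)O)c1` differs from compound 2 in one place: pyridin-3-yl in place of phenyl on a saturated chain carbon bound to an amine nitrogen. Among the measured compounds shown here, the one measured step at this place is a 1.3-fold lower number from compound 1 to compound 2 (0.12 log units; within the scatter). For the measured compounds named here, that step exchanged a different pair of groups, and no measured step adds a ring hetero atom, so it bears only loosely. No change beyond the scatter is expected in this assay, and the estimated step is a 1.0-fold higher number from compound 2 to compound 3 (0.02 log units; within the scatter). For compound 3 the expected value is 17000 nM, with an estimated range of 7000 nM to 40000 nM.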

Compound 3, half-maximal inhibitory concentration: 75000 nM
Compound 3: the middle estimate sits 4.4-fold (0.64 log units) below what was measured; measured number outside the range, above it.
By their numbers in this assay, from the lowest: compounds 2 and 1 (each within the scatter of the next); then compound 3.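

Working from this assay, the place on the saturated chain carbon bound to an amine nitrogen is not indifferent to its group: pyridin-3-yl in place of phenyl gives a 4.6-fold higher number from compound 2 to compound 3 (0.67 log units; beyond the scatter), and pyridin-3-yl in place of isopropyl gives a 3.5-fold higher number from compound 1 to compound 3 (0.55 log units; beyond the scatter). Isopropyl and phenyl lie within the scatter of each other, so only the ring with a hetero atom separates here. No measurement on hand accounts for this change.

Going by these compounds, whether the shift is specific to pyridin-3-yl stays open. Pyridin-4-yl, cyclohexyl or a longer chain at this place would test how far it extends.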